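A few compounds are considered here, and "the series" means these few. Any claim that something is new, unique, unknown or untested is made for them only; others in the source may bear on it.

Compound 1 `COc1nn(-c2ccccn2)c2cc(-c3ccc([C@H]4C[C@@H]4C(=O)O)cc3)cc(F)c12`: 8200 nM
Compound 2 `COc1nn(-c2ccccn2)c2cc(-c3ccc([C@H]4C[C@@H]4C(=O)O)cc3)ccc12`: 5400 nM
Compound 3 `COc1nn(-c2ccc(C)cc2)c2cc(-c3ccc([C@H]4C[C@@H]4C(=O)O)cc3)cc(F)c12`: not yet measured

For the measured compounds named here, in an ADME assay on the whole organism for pharmacokinetics, with Mus musculus as the target, with a stated time of 24 h, at a dose of 5 mg/kg by the oral route (a higher number here means more compound in the circulation at the dose given, a lower number less compound in the circulation), compound 1 gives 8200 nM, which lies within the scatter of the only other measured compound, compound 2. Compound 3 keeps the core of compound 1 and differs from it on an aromatic nitrogen of a five-membered aromatic ring, where 4-methylphenyl stands in place of pyridin-2-yl: 4-methylphenyl in place of pyridin-2-yl on an aromatic nitrogen. Going by the values given here, no measured step touches that place, so the data give no direction for this change. Among the compounds with values here, the one measured step, a 1.5-fold lower number from compound 1 to compound 2 (0.18 log units; within the scatter), concerns hydrogen in place of fluoro on an aromatic carbon and bears on the question only loosely, as a single example of step size. A step within the scatter is therefore expected in this assay, with a wide margin either way. The expected step is a 1.6-fold lower number from compound 1 to compound 3 (0.21 log units; within the scatter). For compound 3 the estimate is 5000 nM, with an expected range of 1500 nM to 14000 nM.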

Compound 3, maximal plasma concentration: 5000 nM
Beside the measured number, compound 3's estimate shows no gap at the digits printed; low and high end bracket the measured number.
By their numbers in this assay, from the lowest: compounds 3, 2 and 1 (each within the scatter of the next).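

For the compounds shown here, on an aromatic nitrogen of the five-membered aromatic ring, the first measured change at this place, 4-methylphenyl in place of pyridin-2-yl, gives a 1.6-fold lower number from compound 1 to compound 3 (0.21 log units; within the scatter) in this assay. With the fluoro group of compound 1 kept, a six-membered aromatic ring of carbon only, with no hydrogen-bond acceptor, thus stands in this place for one with a hetero atom and a hydrogen-bond acceptor, and the step stays within the scatter. Nothing measured speaks to why this read-out holds across the change.

From the compounds shown here alone, whether a saturated ring, a small alkyl group such as methyl, or a ring carrying an amine on that nitrogen would leave the number as close remains open. Also open, going by these compounds, is whether the same exchange gives a similar step when hydrogen replaces the fluoro group.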